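Swapping dimethylamino for hydroxy on the aromatic ring

The source may report more compounds than this note shows. Statements on the series, on what has been measured and on what is new or still open speak of the compounds shown alone.

In a functional assay on PC-3 cells (Homo sapiens) for cytotoxicity, read by sulforhodamine B assay, with a stated time of 48 h (a higher number here means a weaker inhibitor, a lower number a stronger inhibitor), compound 1 (`COc1ccc(C2=NO[C@]3(C2)C(=O)O[C@@H]2[C@H]3CC[C@H](C)[C@]3(O)C=CC(=O)[C@@]23C)cc1`) reads 35000 nM while compound 2 (`C[C@H]1CC[C@@H]2[C@@H](OC(=O)[C@]23CC(c2ccc(N(C)C)cc2)=NO3)[C@]2(C)C(=O)C=C[C@@]12O`) holds the lower of the two numbers at 6300 nM and so is the stronger inhibitor. Compound 3 (`C[C@H]1CC[C@@H]2[C@@H](OC(=O)[C@]23CC(c2ccc(O)cc2)=NO3)[C@]2(C)C(=O)C=C[C@@]12O`) carries hydroxy in place of dimethylamino on an aromatic carbon. Among the measured compounds shown here, the only measured step that bears on this is a 5.6-fold lower number from compound 1 to compound 2 (0.74 log units; beyond the scatter) with dimethylamino in place of methoxy, so leaving dimethylamino is expected to bring a modest rise in this assay although hydroxy itself is untested. For compound 3 the estimated value is 20000 nM (range 7000 nM to 60000 nM). The expected change is a 3.2-fold higher number from compound 2 to compound 3 (0.50 log units; beyond the scatter) in this estimate.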

Compound 3, half-maximal inhibitory concentration: 20000 nM
Estimate against measurement, compound 3: no gap at the digits printed; the range from low to high includes it.
By their numbers in this assay, from the lowest: compound 2; then compounds 3 and 1 (each within the scatter of the next).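

In this assay, a second replacement for dimethylamino at this place on the ring also gives a weaker result, with hydroxy showing a 3.2-fold higher number from compound 2 to compound 3 (0.50 log units; beyond the scatter), so dimethylamino now holds its lead over both oxygen-linked groups. Hydroxy and methoxy cannot be told apart, with a 1.8-fold lower number from compound 1 to compound 3 (0.24 log units; within the scatter), so losing the methyl from that oxygen makes no readable difference. Nothing measured here explains why dimethylamino stands apart. From the compounds shown here alone, whether a plain amino group or a morpholine would match dimethylamino at this place remains open, as does the effect of a carboxylic acid there.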